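The source may report more compounds than this note shows. Statements on the series, on what has been measured and on what is new or still open speak of the compounds shown alone.

Measured so far:

Compound 1 `CC1CCN(c2c(S(=O)(=O)c3ccc(C#N)cc3)cnc3cc(Cl)ccc23)CC1`: 70%
Compound 2 `CC1CCN(c2c(S(=O)(=O)c3cc(Cl)cc(Cl)c3)cnc3cc(F)ccc23)CC1`: 87%

Both numbers come from an assay on isolated protein for displacement of a labelled ligand from metabotropic glutamate receptor 5 (Homo sapiens), with a stated time of 60 min, tested at 1 uM; on this read-out higher numbers stand for more inhibition at the one concentration tested (going by the name of the read-out) and lower numbers for less inhibition. Compound 2 gives the higher of the two numbers, and compound 1 sits a distance below it that is beyond the usual scatter of repeated measurements. The two compounds differ from each other in more than one place, so nothing can be said about any single change between them; only their two values are known.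

Compound 3 `CC1CCN(c2c(S(=O)(=O)c3cc(Cl)cc(Cl)c3)cnc3cc(Cl)ccc23)CC1` has not yet been measured. It differs from compound 2 in a single place: chloro in place of fluoro on an aromatic carbon. Fluoro leaves and chloro enters on an aromatic carbon of the six-membered carbon ring that forms part of the fused two-ring system, the rest of the molecule staying as in compound 2.

Among the compounds with values here, no measured pair shows this exact exchange, so the expected step from compound 2 to compound 3 in this assay is estimated to be small, close to none beyond the scatter, a number 2 percentage points lower from compound 2 to compound 3 (within the scatter). Compound 3 is therefore expected to give about 85%, within a range from 70% to 96%.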

Compound 3, a percentage reported as inhibition, at one concentration (the size of the read-out at that concentration, not a potency): 93%
Compound 3: the middle estimate sits 8 percentage points below what was measured; low and high end bracket the measured number.
By their numbers in this assay, from the lowest: compound 1; then compounds 2 and 3 (each within the scatter of the next).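

In this assay, chloro in place of fluoro on an aromatic carbon gives a number 6 percentage points higher from compound 2 to compound 3 (within the scatter), so with the 3,5-dichlorophenyl group held constant, these two halogens cannot be told apart at this position. The second single-place comparison concerns the sulfonyl sulfur, where 3,5-dichlorophenyl in place of 4-cyanophenyl gives a number 23 percentage points higher from compound 1 to compound 3 (beyond the scatter); unlike the halogen exchange, this step lies beyond the scatter. Nothing available explains either step or shows how these groups act on the receptor.

The compounds shown leave open whether a methoxy group or a plain hydrogen on that aromatic carbon would keep the inhibition, and how an amine or a carboxylic acid on the sulfonyl-bound ring would fare. Since each number comes from one concentration, the potency of these compounds also remains open.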